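Butyl for Hydroxy on the Side Chain: Compound 4

This account rests on a few compounds, and the source may have more. Where it says the series, first, only, none or still open, it means among the compounds named here.

Four close relatives share one core. Compound 1 `CCCCCCNc1nc(-c2ccccc2)nc2c1nnn2Cc1ccccc1` carries a hexylamino chain, compound 2 `OCCNc1nc(-c2ccccc2)nc2c1nnn2Cc1ccccc1` a (2-hydroxyethyl)amino chain, and compound 3 `OCCNc1nc(-c2ccccc2)nc2c1nnn2Cc1ccccc1F` adds a fluoro group to the benzyl ring of compound 2. In an assay on isolated protein for binding affinity to adenosine receptor A1 (Bos taurus) (on this read-out lower numbers stand for stronger inhibition and higher numbers for weaker inhibition), compound 1 gives 13200000 nM, compound 2 gives 38000000 nM and compound 3 gives 54000000 nM.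

Two steps connect them. Compound 2 and compound 3 differ by fluoro in place of hydrogen on an aromatic carbon, and this gives a 1.4-fold higher number from compound 2 to compound 3 (0.15 log units; within the scatter). Compound 2 and compound 1 differ by butyl in place of hydroxy on a saturated chain carbon, two bonds along the chain from a nitrogen on an aromatic ring, and this gives a 2.9-fold lower number from compound 2 to compound 1 (0.46 log units; beyond the scatter).

Compound 4 `CCCCCCNc1nc(-c2ccccc2)nc2c1nnn2Cc1ccccc1F` is still unmeasured. Among the compounds with values here, it differs from compound 3 by butyl in place of hydroxy on a saturated chain carbon, two bonds along the chain from a nitrogen on an aromatic ring, which is the same change as the one from compound 2 to compound 1, here made on the fluorinated core. Since the fluoro group barely moved the number, the step of a 2.8-fold lower number from compound 3 to compound 4 (0.45 log units; beyond the scatter) in this assay is expected to resemble a 2.9-fold lower number from compound 2 to compound 1 (0.46 log units; beyond the scatter). On that basis compound 4 is expected to show about 19000000 nM, plausibly between 9000000 nM and 40000000 nM.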

Compound 4, inhibition constant: 25000000 nM
Compound 4: the middle estimate sits 1.3-fold (0.12 log units) below what was measured; the measured number falls inside the stated range.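

Replacing the (2-hydroxyethyl)amino chain with the hexylamino chain on the fluorinated core gives a 2.2-fold lower number from compound 3 to compound 4 (0.33 log units; beyond the scatter) in this assay, and this step agrees with its counterpart on the core without fluoro: the same change on two cores in this assay, a 2.9-fold lower number (0.46 log units; beyond the scatter) from compound 2 to compound 1 and a 2.2-fold lower number (0.33 log units; beyond the scatter) from compound 3 to compound 4, 1.3-fold (0.12 log units) apart, within the scatter of two such steps. Adding the fluoro group to the compound with the hexylamino chain gives a 1.9-fold higher number from compound 1 to compound 4 (0.28 log units; within the scatter), and this step likewise agrees with the one seen on the (2-hydroxyethyl)amino compound: the same change on two cores in this assay, a 1.4-fold higher number (0.15 log units; within the scatter) from compound 2 to compound 3 and a 1.9-fold higher number (0.28 log units; within the scatter) from compound 1 to compound 4, 1.3-fold (0.12 log units) apart, within the scatter of two such steps. Within these four compounds, each change therefore carried from one core to the other with no difference beyond the scatter, but this does not explain why, and a single pair of cores cannot establish that the same would hold across the rest of the series.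

From the compounds shown here alone, it remains open whether a longer chain, or a chain carrying an amine or a carboxylic acid, would follow the same pattern. Going by these compounds, it is equally open whether chloro in place of the fluoro group would leave the chain step unchanged.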